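A few compounds are considered here, and "the series" means these few. Any claim that something is new, unique, unknown or untested is made for them only; others in the source may bear on it.

Compound 1 `Cc1ccc(-n2nc(-c3ccc(C(F)(F)F)cc3O)nc2-c2ccccc2O)cc1`: 102%
Compound 2 `CC(C)c1ccc(-n2nc(-c3ccc(C(F)(F)F)cc3O)nc2-c2ccccc2O)cc1`: 108%
Compound 3 `Oc1cc(C(F)(F)F)ccc1-c1nc(-c2ccccc2O)n(-c2ccc(F)cc2)n1`: 99.8%

In a functional assay on PC-12 cells (Rattus norvegicus) for cytotoxicity, read by MTT assay, with stated times of 2 h and 24 h, tested at 10 uM (a lower number here means a weaker effect, a higher number a stronger effect of the compound at the concentration tested), compound 1 stands second highest of the three numbers; the nearest is compound 3, with a step of a number 2.2 percentage points lower from compound 1 to compound 3 (within the scatter), and the furthest is compound 2, with a step of a number 6 percentage points higher from compound 1 to compound 2 (within the scatter). Compound 4 `Cc1cc(C)cc(-n2nc(-c3ccc(C(F)(F)F)cc3O)nc2-c2ccccc2O)c1` differs from compound 1 in one place: 3,5-dimethylphenyl in place of 4-methylphenyl on an aromatic nitrogen. All three measured steps alter the group carried on that same aromatic nitrogen, and each remained within the scatter: a number 6 percentage points higher from compound 1 to compound 2 (within the scatter), a number 2.2 percentage points lower from compound 1 to compound 3 (within the scatter), and a number 8.2 percentage points lower from compound 2 to compound 3 (within the scatter). Because these steps a number 6 percentage points higher from compound 1 to compound 2 (within the scatter) and a number 2.2 percentage points lower from compound 1 to compound 3 (within the scatter) show no movement beyond the scatter, no step beyond the scatter is expected here either, so the expected step is a number 1 percentage points higher from compound 1 to compound 4 (within the scatter). Compound 4 is therefore estimated at 103%, with a range from 92% to 114%.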

Compound 4, a percentage reported as activity, at one concentration (the size of the read-out at that concentration, not a potency): 105%
The estimate for compound 4 lay 2 percentage points below the measured number; the measured number falls inside the stated range.
By their numbers in this assay, from the lowest: compounds 3, 1, 4 and 2 (each within the scatter of the next).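

Compound 4 is the first of these compounds to carry two methyl groups on the phenyl ring at the aromatic nitrogen, and in this assay the steps are a number 3 percentage points higher from compound 1 to compound 4 (within the scatter) and a number 5.2 percentage points higher from compound 3 to compound 4 (within the scatter) and a number 3 percentage points lower from compound 2 to compound 4 (within the scatter) in this read-out. Thus 3,5-dimethylphenyl joins 4-methylphenyl, 4-fluorophenyl and 4-isopropylphenyl as a group whose steps all stay within the scatter. No measurement is available to explain these numbers. The compounds shown leave open whether an amine or a carboxylic acid on this phenyl ring would give a step beyond the scatter.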